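The source may hold more compounds than are shown below. What is called first, only, known or untested is meant among the compounds shown, and "the series" means these compounds.

Working notes on the series. Among the compounds with values here, compound 1 `CCCCNC(=O)N1CC1C#N` carries a butyl chain on the shared core; in a functional assay on WiDr cells (Homo sapiens) for inhibition (a higher number here means a weaker inhibitor, a lower number a stronger inhibitor), compound 1 gives 18000 nM, the highest of the three numbers so far. Within the data shown here, compound 2 `N#CC1CN1C(=O)Nc1ccc(F)cc1` gives 9000 nM in this assay, a number within the scatter of the one for compound 1. Compound 3 `N#CC1CN1C(=O)Nc1cccc2ccccc12` gives 2500 nM in this assay, a lower number than compound 1 by more than the scatter. Among the measured compounds shown here, compound 2 and compound 3 differ from compound 1 in more than one place, so no single-change step between measured compounds is available to size the next comparison.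

Compound 4 `CCNC(=O)N1CC1C#N` differs from compound 1 by hydrogen in place of ethyl on a saturated chain carbon, two bonds along the chain from an amide-type nitrogen. Nothing measured tracks the chain length itself, and the change removes atoms rather than adding them. The expectation for compound 4 in this assay is a step of a 1.4-fold higher number from compound 1 to compound 4 (0.14 log units; within the scatter) that stays within or only just beyond the scatter, toward a weaker inhibitor if anything. Compound 4 is estimated at 25000 nM, with a range from 8000 nM to 80000 nM.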

Compound 4, half-maximal inhibitory concentration: 7000 nM
Estimate against measurement, compound 4: 3.6-fold (0.55 log units) above; measured number outside the range, below it.
By their numbers in this assay, from the lowest: compound 3; then compounds 4, 2 and 1 (each within the scatter of the next, the first and the last beyond it).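

Within the data shown here, at this position the outer ethyl of the butyl chain is not needed for inhibition: cutting the chain from butyl to ethyl gives a 2.6-fold lower number from compound 1 to compound 4 (0.41 log units; beyond the scatter) in this assay, the first single-change reading. The step is modest, but it runs toward a stronger inhibitor, so in this pair the removal of chain carbons two bonds along from the amide-type nitrogen costs no inhibition. Nothing available bears on what lies behind the shift.

Among these compounds, with only two chain lengths in a single pair, no trend with chain length can be drawn. A propyl or methyl chain, a longer chain such as hexyl, and an amine at the chain end would each show whether the direction of this step holds.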